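Extending the Methoxy Group into a Hydroxybutoxy Chain

A few compounds are considered here, and "the series" means these few. Any claim that something is new, unique, unknown or untested is made for them only; others in the source may bear on it.

In an assay on COS-7 cells for inhibition of sodium/nucleoside cotransporter 2 (Homo sapiens), read by scintillation counting (a higher number here means a weaker inhibitor, a lower number a stronger inhibitor), compound 2 `COc1cc(CNc2nc3c(N)ncnc3n2[C@@H]2O[C@H](CO)[C@@H](O)[C@H]2O)ccc1-c1ccccc1` gives 1300 nM, the higher of the two numbers shown, though the gap to compound 1 lies within the scatter. Going by the values given here, compound 1 `Nc1ncnc2c1nc(NCc1ccc(-c3ccccc3)c(O)c1)n2[C@@H]1O[C@H](CO)[C@@H](O)[C@H]1O` gives 1200 nM in this assay, and the only measured step, a 1.1-fold higher number from compound 1 to compound 2 (0.03 log units; within the scatter), concerns the same oxygen. Compound 3 `Nc1ncnc2c1nc(NCc1ccc(-c3ccccc3)c(OCCCCO)c1)n2[C@@H]1O[C@H](CO)[C@@H](O)[C@H]1O` differs from compound 2 by 3-hydroxypropyl in place of hydrogen on a saturated chain carbon bound to an oxygen on an aromatic ring. Because a 1.1-fold higher number from compound 1 to compound 2 (0.03 log units; within the scatter) stayed within the scatter, no step beyond the scatter is expected for compound 3, whose value in this assay is estimated at 1300 nM with a range of 500 nM to 3500 nM. The expected step is no change at the digits printed from compound 2 to compound 3 (within the scatter).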

Compound 3, half-maximal inhibitory concentration in the sodium/nucleoside cotransporter 2 assay: 940 nM
Beside the measured number, compound 3's estimate is 1.4-fold (0.14 log units) above it; the range from low to high includes it.
By their numbers in the sodium/nucleoside cotransporter 2 assay, from the lowest: compounds 3, 1 and 2 (each within the scatter of the next).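

In the sodium/nucleoside cotransporter 2 assay compound 1 gives 1200 nM, compound 2 gives 1300 nM and compound 3 gives 940 nM. In the sodium/nucleoside cotransporter 2 assay, 4-hydroxybutoxy in place of methoxy gives a 1.4-fold lower number from compound 2 to compound 3 (0.14 log units; within the scatter), and 4-hydroxybutyl in place of hydrogen on the oxygen gives a 1.3-fold lower number from compound 1 to compound 3 (0.11 log units; within the scatter), so neither replacement on this oxygen goes beyond the scatter. In a physicochemical assay for solubility, with a stated time of 1 h, at 37 degrees C, at pH 6.8 (on this read-out lower numbers stand for lower solubility and higher numbers for higher solubility), compound 2 gives 215 ug/mL and compound 3 gives 190 ug/mL. In the physicochemical assay the same change gives a 1.1-fold lower number from compound 2 to compound 3 (0.05 log units; within the scatter), which also shows no change beyond the scatter. No measurement is available here to explain either result.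

Still open, from the compounds shown here alone, is whether an amine, a carboxylic acid or a longer chain on this oxygen would shift the number in the sodium/nucleoside cotransporter 2 assay beyond the scatter.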